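A few compounds are considered here, and "the series" means these few. Any claim that something is new, unique, unknown or untested is made for them only; others in the source may bear on it.

Measured so far:
compound 1 `COc1cc(OC)c(/C=C/S(=O)(=O)Cc2ccc(OC)c(N)c2)c(OC)c1` gives < 10 nM;
compound 2 `COc1ccc(CS(=O)(=O)/C=C/c2c(OC)cccc2OC)cc1[N+](=O)[O-]` gives 13700 nM;
compound 3 `COc1ccc(CS(=O)(=O)CC(=O)Nc2ccccc2)cc1N` gives > 30000 nM.

All three were tested in a functional assay on MCF7 cells (Homo sapiens) for cytotoxicity, read by MTT assay, with a stated time of 72 h; on this read-out lower numbers stand for stronger inhibition of growth and higher numbers for weaker inhibition of growth. For compound 1 the result is a limit of the assay, (the limit of < 10 nM in this assay, at which 1 of the 3 values shown sits), not a number. For compound 3 the result is likewise a limit, (the limit of > 30000 nM in this assay, at which 1 of the 3 values shown sits). Compound 2 is therefore the only one of the three with a measured number, and it stands alone among the values shown.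

Compound 4 `COc1ccc(CS(=O)(=O)/C=C/c2c(OC)cccc2OC)cc1N` has not yet been measured. It differs from compound 2 in a single place: amino in place of nitro on an aromatic carbon. Compound 1, which also carries an amino group on its benzyl ring, sits at the lower limit of the assay, while compound 2 with its nitro group gives a number far from that limit. For the measured compounds named here, no measured pair that differs only in this exchange is available, so the size of the step cannot be taken from data. Still, going from compound 2 to compound 4 a step toward stronger inhibition of growth, well beyond the usual scatter, is expected, a 69-fold lower number from compound 2 to compound 4 (1.84 log units; beyond the scatter). For compound 4 the value is estimated at 200 nM, within a range from 20 nM to 3000 nM.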

Compound 4, concentration for 50% growth inhibition: 40 nM
Beside the measured number, compound 4's estimate is 5.0-fold (0.70 log units) above it; the measured number falls inside the stated range.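

In this assay, for the compounds shown here, the exchange at this position, on an aromatic carbon ortho to a methoxy group, can now be read directly for the first time: amino in place of nitro gives a 340-fold lower number from compound 2 to compound 4 (2.53 log units; beyond the scatter), a large step that no earlier pair could show. With the amino group kept, a second single change also matters, as hydrogen in place of methoxy on an aromatic carbon gives an at least 4.0-fold higher number from compound 1 to compound 4 (0.60 log units; beyond the scatter). The result for compound 1 in that comparison is a limit and not a number: the limit of < 10 nM in this assay, at which 1 of the 4 values shown sits.

Only amino and nitro are shown at this position, so it remains open whether a hydroxyl, a methylamino or an acetamide group there would give a number closer to that of the amino group or to that of the nitro group. Going by these compounds alone, these values also do not tell why the exchange moves the number so far, or whether it would move the core of compound 1 by a similar amount.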